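The compounds below may be only part of what the source reports. "The series", "measured", "known", "first", "only" and "open" are said of these compounds alone.

Working notes on the series. Compound 2 `COc1cccc(OCCCCCN2CCCC(COC(=O)c3ccccc3N3C(=O)CC(C)C3=O)C2)c1OC` and compound 1 `COc1ccc(OCCCCCN2CCCC(COC(=O)c3ccccc3-c3ccccc3)C2)cc1` share the piperidine-linked ester core and the five-carbon chain to an aryl ether; they differ at the ester aryl group and at the aryl ether. For the measured compounds named here, in an in vitro functional assay on HEK ts201 cells for antagonist activity at Neuronal acetylcholine receptor; alpha4/beta2 (Homo sapiens), read by fluorescence and calcium flux (a lower number here means a stronger inhibitor, a higher number a weaker inhibitor), compound 2 gives 8710 nM, and compound 1 gives 14500 nM; the two numbers lie within the scatter of each other, so compound 2 stands level with compound 1 on the numbers so far. Compound 3 `COc1ccc(OCCCCCN2CCCC(COC(=O)c3ccccc3N3C(=O)CC(C)C3=O)C2)cc1` is not yet measured. It keeps the ester of compound 2 and differs only in 4-methoxyphenyl in place of 2,3-dimethoxyphenyl on an oxygen on a saturated carbon. Going by the values given here, no measured pair isolates this change. Compound 1 carries the same 4-methoxyphenyl ether and sits within the scatter of compound 2, which gives no ground for expecting a step beyond the scatter. The expected step from compound 2 to compound 3 in this assay is a 1.1-fold higher number from compound 2 to compound 3 (0.06 log units; within the scatter), none beyond the scatter. Compound 3 is estimated at 10000 nM, with a range of 4000 nM to 30000 nM.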

Compound 3, half-maximal inhibitory concentration: 14500 nM
For compound 3 the middle estimate is 1.5-fold (0.16 log units) below the measured one; the measured number falls inside the stated range.
By their numbers in this assay, from the lowest: compounds 2, 1 and 3 (each within the scatter of the next).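

Two single changes can now be read on their own. In this assay, 4-methoxyphenyl in place of 2,3-dimethoxyphenyl on an oxygen on a saturated carbon gives a 1.7-fold higher number from compound 2 to compound 3 (0.22 log units; within the scatter), and 3-methyl-2,5-dioxopyrrolidin-1-yl in place of phenyl on an aromatic carbon gives no change at the digits printed from compound 1 to compound 3 (within the scatter), so neither swap separates its pair beyond the scatter in this set. No other data bear on these results.

All the steps among these three compounds lie within the scatter, so neither position has yet shown a step that can be told from it. On these data alone, it remains open whether an amine or a carboxylic acid on the aryl ether, or a longer chain to that ether, would give a step beyond the scatter.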